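Five-membered ring changes at the aryl-imidazoline series

The compounds below may be only part of what the source reports. "The series", "measured", "known", "first", "only" and "open" are said of these compounds alone.

Measured compounds:
compound 1 `c1coc(-c2ccccc2NCC2=NCCN2)c1`, 6.31 nM
compound 2 `Cc1cc(-c2ccccc2NCC2=NCCN2)on1`, 95.5 nM

In a functional assay for activation of Alpha-1B adrenergic receptor (Homo sapiens), read by calcium flux (a higher number here means that more compound is needed for the effect, a lower number that less compound is needed), compound 1 gives 6.31 nM and compound 2 gives 95.5 nM. Among the compounds with values here, compound 2 therefore stands at the higher of the two numbers: the step of a 15-fold higher number from compound 1 to compound 2 (1.18 log units; beyond the scatter) is the only measured step in the set, and it shows that exchanging one five-membered aromatic ring for another on the shared core can move this assay by a large amount.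

Compound 3 `c1ccc(-c2cnoc2)c(NCC2=NCCN2)c1` has not been measured. It differs from compound 2 in one place: 1,2-oxazol-4-yl in place of 3-methyl-1,2-oxazol-5-yl on an aromatic carbon. Within the data shown here, no measured step covers this exact exchange; the step from compound 1 to compound 2 bears on it only as a sign that the identity of the five-membered ring matters a great deal here. The direction of the new change cannot be read from the data, so compound 3 is expected near compound 2, with wide uncertainty, giving an estimated step of a 1.9-fold lower number from compound 2 to compound 3 (0.28 log units; within the scatter). For compound 3 the estimated value in this assay is 50 nM, in the range 8 nM to 300 nM.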

Compound 3, half-maximal effective concentration: < 100000 nM
Compound 3: a limit, no number; the forecaster's own chance of this, stated with the estimate: 5%; the middle value lies beyond the limit too.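

In this assay compound 3 gives < 100000 nM, which is a limit of the assay and not a number. The steps to compound 3 from compound 1 and compound 2 therefore cannot be read. The compounds shown leave open how 1,2-oxazol-4-yl compares with furan-2-yl and 3-methyl-1,2-oxazol-5-yl on the shared core.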